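The compounds below may be only part of what the source reports. "The series", "measured", "known", "first", "only" and "open" are said of these compounds alone.

Measured compounds:
- compound 1, `O=C1Nc2ccc(OCc3cccc(Cl)c3)cc2C1=O`: 311000 nM
- compound 2, `CCn1c(=O)[nH]c2ccc(OCCCOc3ccccc3)cc21`: "not determined" (no result reported)

Within the data shown here, only one number is on record here. Among the measured compounds shown here, in an assay on cells for inhibition of Amine oxidase [flavin-containing] A (Homo sapiens), read by fluorescence, with stated times of 30 min and 15 min (on this read-out lower numbers stand for stronger inhibition and higher numbers for weaker inhibition), compound 1 gives 311000 nM, a very weak effect, and it is the only compound with a value, since for compound 2 no result was reported. Compound 3, `O=C1Nc2ccc(OCc3ccc(Cl)c(Cl)c3)cc2C1=O`, has not yet been measured. It differs from compound 1 in one place: chloro in place of hydrogen on an aromatic carbon, a chloro in place of hydrogen on an aromatic carbon, ortho to a chloro group and para to a large group. For the measured compounds named here, no step between measured compounds exists to guide an expectation, so the change from compound 1 to compound 3 is expected to stay within the usual scatter, with at most a slight gain in inhibition, as a 1.6-fold lower number from compound 1 to compound 3 (0.19 log units; within the scatter). Compound 3 is therefore expected to give about 200000 nM, with a likely range from 60000 nM to 600000 nM.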

Compound 3, half-maximal inhibitory concentration: 117000 nM
Beside the measured number, compound 3's estimate is 1.7-fold (0.23 log units) above it, within the range that was stated.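

In this assay, among these compounds, putting a chloro in place of hydrogen on this aromatic carbon, ortho to a chloro group and para to a large group, gives a 2.7-fold lower number from compound 1 to compound 3 (0.42 log units; beyond the scatter) as the only step available. Among the compounds shown here, this is the first sign that this carbon of the ring can influence inhibition: the step is modest but lies beyond the usual scatter, although compound 3 remains a weak inhibitor. No supporting measurement is available to explain the change.

Going by these compounds, it remains open whether this gain is specific to chloro or would also appear with another group at the same carbon, such as fluoro, methyl or methoxy. Also open, on these data alone, is how inhibition would respond to a longer chain joining the chlorinated ring to the core of compound 3.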